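From a hydroxyphenyl to a dimethoxyphenyl compound

This account rests on a few compounds, and the source may have more. Where it says the series, first, only, none or still open, it means among the compounds named here.

Measured in a functional assay on HeLa cells (Homo sapiens) for inhibition, read by MTT assay, with a stated time of 48 h; on this read-out lower numbers stand for stronger inhibition and higher numbers for weaker inhibition:
compound 1 `c1ccc(C(c2c[nH]c3ccccc23)c2c[nH]c3ccccc23)cc1`: 21800 nM
compound 2 `Brc1ccc2[nH]cc(C(c3ccccc3)c3c[nH]c4ccc(Br)cc34)c2c1`: 900 nM
compound 3 `Oc1cccc(C(c2c[nH]c3ccc(Br)cc23)c2c[nH]c3ccc(Br)cc23)c1`: 3900 nM

Of these three numbers, compound 3 holds the second highest. Compound 1 reads higher and compound 2 reads lower, and both gaps lie beyond the usual scatter.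

The next compound is compound 4 `COc1cccc(C(c2c[nH]c3ccc(Br)cc23)c2c[nH]c3ccc(Br)cc23)c1OC`, which has not yet been measured. Its structural difference from compound 3 is 2,3-dimethoxyphenyl in place of 3-hydroxyphenyl on a saturated chain carbon bound to two aromatic carbons. In words, it has 2,3-dimethoxyphenyl in place of 3-hydroxyphenyl on a saturated chain carbon bound to two aromatic carbons.

Among the measured compounds shown here, only one measured step bears on this change: a 4.3-fold higher number from compound 2 to compound 3 (0.64 log units; beyond the scatter). That modest step came with hydroxy in place of hydrogen on an aromatic carbon. Compound 4 no longer carries that hydroxy, which hints at a move back towards lower numbers. For the measured compounds named here, no measured compound here carries a methoxy group, however, so this step is only a weak guide. In this assay, a small step to a lower number is therefore expected, probably no larger than the scatter. The estimated step is a 1.6-fold lower number from compound 3 to compound 4 (0.19 log units; within the scatter). For compound 4 the estimated value is 2500 nM, with an expected range from 800 nM to 8000 nM.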

Compound 4, half-maximal inhibitory concentration: 64500 nM
For compound 4 the middle estimate is 26-fold (1.41 log units) below the measured one; measured number outside the range, above it.
By their numbers in this assay, from the lowest: compound 2; then compound 3; then compound 1; then compound 4.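

In this assay, the change to 2,3-dimethoxyphenyl gives a 17-fold higher number from compound 3 to compound 4 (1.22 log units; beyond the scatter), and set against the unsubstituted phenyl it gives a 72-fold higher number from compound 2 to compound 4 (1.86 log units; beyond the scatter). Taking away the hydroxy therefore does not by itself bring the number back down: the group on this saturated chain carbon can move the number much further than the earlier, modest step (a 4.3-fold higher number from compound 2 to compound 3 (0.64 log units; beyond the scatter)) suggested, and here it moves it upwards. Nothing measured here accounts for the size of this rise, so it stands as an observation without an explanation.

Compound 4 loses the hydroxy and gains two methoxy groups in a single change, so the compounds shown cannot say how much of the rise belongs to each, or whether a ring with just one methoxy group would read closer to compound 3 or to compound 4. They also leave open how a phenyl ring carrying an amine, a carboxylic acid or a longer alkoxy chain would read at this same place.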